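The source may report more compounds than this note shows. Statements on the series, on what has been measured and on what is new or still open speak of the compounds shown alone.

Measured in a functional assay on the whole organism (strain CD1) for inhibition, with Mus musculus as the target, with stated times of 15 min and 20 min, at a dose of 10 mg/kg by the subcutaneous route; a higher number here means more inhibition at the dose given (going by the name of the read-out), a lower number less inhibition:
compound 1 `CCOC(=O)/C(C#N)=C/c1ccc(O)c(O)c1` gives 57.8%.
compound 2 `N#C/C(=C\c1ccc(O)c(O)c1)C(=O)OC1CCCCC1` gives 55.3%.
compound 3 `CCOC(=O)/C(C#N)=C/c1c[nH]cn1` gives 33%.

Within the pair sharing the core of compound 1, the change cyclohexyl in place of ethyl on an oxygen next to a carbonyl group produced a number 2.5 percentage points lower from compound 1 to compound 2 (within the scatter). Compound 3 carries a different core; how the two cores differ is not broken down here, and compound 3 shows the lowest of the three numbers, beyond the scatter from both compound 1 and compound 2.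

Compound 4 `N#C/C(=C\c1c[nH]cn1)C(=O)OC1CCCCC1` is compound 3 with the same change applied, (cyclohexyl in place of ethyl on an oxygen next to a carbonyl group), at a place described in the same words. From the compounds shown here alone, the step is expected to be small, a number 2 percentage points lower from compound 3 to compound 4 (within the scatter), because a number 2.5 percentage points lower from compound 1 to compound 2 (within the scatter) stayed within the scatter; whether this carries over to the core of compound 3 is untested. Compound 4 is therefore estimated at 31%, with a range from 16% to 46%.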

Compound 4, a percentage reported as inhibition, in the whole organism at one dose (the size of the read-out at that dose, not a potency): 50%
Compound 4: the middle estimate sits 19 percentage points below what was measured; measured number outside the range, above it.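

In this assay, cyclohexyl in place of ethyl on an oxygen next to a carbonyl group gave a number 17 percentage points higher from compound 3 to compound 4 (beyond the scatter), and the size of the step depends on the core: the same change on two cores in this assay, a number 2.5 percentage points lower (within the scatter) from compound 1 to compound 2 and a number 17 percentage points higher (beyond the scatter) from compound 3 to compound 4, 19.5 percentage points apart, beyond the scatter of two such steps

The step on the core of compound 1 therefore gives no reliable forecast of the step on the core of compound 3. Among the compounds shown here, with one pair per core, this shows only that the two steps differ, not why they differ or how the change would behave on any further core.

Still open, from the compounds shown here alone, is how a longer chain or a benzyl group on the same oxygen would compare with ethyl and cyclohexyl on each core. Also open, going by these compounds, is how a carboxylic acid or an amide would compare at that place.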